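Butyl Ester in Place of the Hydroxyethyl Chain

The source may report more compounds than this note shows. Statements on the series, on what has been measured and on what is new or still open speak of the compounds shown alone.

Of the compounds shown here, two from this series have been measured in a functional assay on HT-29 cells (Homo sapiens) for cytotoxicity, read by MTT assay, with a stated time of 48 h; on this read-out higher numbers stand for weaker inhibition and lower numbers for stronger inhibition. Compound 1, `COc1ccc(CN2C(=O)C(=O)c3cc(/C=C/C(=O)OCCO)ccc32)cc1`, gives 550 nM in this assay, the lowest of the two numbers. Compound 2, `COC(=O)/C=C/c1cccc2c1C(=O)C(=O)N2Cc1ccc(OC)cc1`, differs from compound 1 both in where the unsaturated ester arm is attached to the shared core and in the ester group itself; in this assay compound 2 gives 3120 nM, a gap beyond the usual scatter, though no single-point comparison between the two can be drawn.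

Compound 3, `CCCCOC(=O)/C=C/c1ccc2c(c1)C(=O)C(=O)N2Cc1ccc(OC)cc1`, has not yet been measured. It keeps the core and attachment pattern of compound 1 and changes only the ester chain: ethyl in place of hydroxy on a saturated chain carbon, two bonds along the chain from an oxygen next to a carbonyl group. The chain grows from 2-hydroxyethoxy to butoxy while the rest of the molecule is untouched.

Among the measured compounds shown here, no measured pair isolates this kind of change, so the expectation rests on the position of compound 1 alone. Compound 3 is expected to land close to compound 1, with the step from compound 1 to compound 3 estimated at a 1.4-fold higher number from compound 1 to compound 3 (0.13 log units; within the scatter) in this assay, within or only slightly beyond the scatter. For compound 3 the estimate is therefore 750 nM, in a range from 250 nM to 2200 nM.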

Compound 3, half-maximal inhibitory concentration: 420 nM
Compound 3: the middle estimate sits 1.8-fold (0.25 log units) above what was measured; the range from low to high includes it.
By their numbers in this assay, from the lowest: compounds 3 and 1 (each within the scatter of the next); then compound 2.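

In this assay, ethyl in place of hydroxy on a saturated chain carbon, two bonds along the chain from an oxygen next to a carbonyl group, gives a 1.3-fold lower number from compound 1 to compound 3 (0.12 log units; within the scatter), so this pair cannot be told apart on this read-out. Among the compounds shown here, this is the first comparison that differs in one place, and it shows that, on the shared core with the attachment of compound 1, the hydroxy group can give way to ethyl, turning 2-hydroxyethoxy into butoxy, without a step beyond the scatter. Nothing available bears on the reason for this outcome.

On these data alone, how a methyl ester behaves at the attachment of compound 1 remains open, and with it whether the distance of compound 2 from the other two belongs to the attachment, to the ester group or to both. Also open, as far as these compounds go, is what a carboxylic acid or an amine would do in place of the ester chain, and what a chain longer than butoxy would do at this position.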